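Halogen swap on the urea aryl of a bithiazole urea series

A few compounds are considered here, and "the series" means these few. Any claim that something is new, unique, unknown or untested is made for them only; others in the source may bear on it.

Measured so far:
compound 1, `CNC(=O)c1cc(Oc2ccc3nc(NC(=O)Nc4cc(C(F)(F)F)cc(C(F)(F)F)c4)sc3c2)ccn1`: 87.5%
compound 2, `CNC(=O)c1cc(Oc2ccc3nc(NC(=O)Nc4ccc(Cl)cc4)sc3c2)ccn1`: 57.4%

In a functional assay on HCT-116 cells (Homo sapiens) for inhibition, read by MTT assay, with a stated time of 2 days, tested at 10 uM (a higher number here means more inhibition of growth at the concentration tested, a lower number less inhibition of growth), compound 1 gives 87.5% and compound 2 gives 57.4%, the lower of the two numbers, a gap that lies beyond the usual scatter. Compound 3, `CNC(=O)c1cc(Oc2ccc3nc(NC(=O)Nc4ccc(Br)cc4)sc3c2)ccn1`, differs from compound 2 only in bromo in place of chloro on an aromatic carbon. For the measured compounds named here, no measured pair shows this change, so nothing in the data fixes its size. A step within the scatter, in either direction, is expected; the estimate for compound 3 is 60%, range 45% to 75%, meaning an expected step of a number 2.6 percentage points higher from compound 2 to compound 3 (within the scatter).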

Compound 3, percent growth inhibition at one concentration: 12.1%
Compound 3: the middle estimate sits 47.9 percentage points above what was measured; the measured number lies below the stated range.
By their numbers in this assay, from the lowest: compound 3; then compound 2; then compound 1.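

In this assay the change from 4-chlorophenyl to 4-bromophenyl gives a number 45.3 percentage points lower from compound 2 to compound 3 (beyond the scatter) at this position, so a single halogen exchange on an aromatic carbon, para to a large group, can move the number well beyond the scatter. The pair differs by no ring, hydrogen-bond donor, hydrogen-bond acceptor or net charge, so these counts do not separate compound 2 from compound 3. No available data give a cause for this step. Left open is whether the step belongs to bromo alone or extends to other groups on this carbon, such as fluoro, iodo, methoxy or an amine. A single pair also leaves open whether the same exchange behaves alike elsewhere on the ring.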